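Methoxyethylamine in Place of Acetamide on the Benzylic Carbon

The source may hold more compounds than are shown below. What is called first, only, known or untested is meant among the compounds shown, and "the series" means these compounds.

Measured so far:
Compound 1, `CCC(C)C(N)c1cc(C(F)(F)F)ccc1N1CCN(C(=O)CCc2ccc(Cl)cc2Cl)CC1`: 160 nM
Compound 2, `CCC(C)[C@H](NC(C)=O)c1cc(C(F)(F)F)ccc1N1CCN(C(=O)CCc2ccc(Cl)cc2Cl)CC1`: 360 nM

In an assay on HEK293 cells for displacement of a labelled ligand from Melanocortin receptor 4 (Homo sapiens) (a higher number here means a weaker inhibitor, a lower number a stronger inhibitor), compound 1 gives 160 nM. For the measured compounds named here, compound 2 gives 360 nM, the higher of the two numbers measured so far. Going by the values given here, the single measured step, a 2.3-fold higher number from compound 1 to compound 2 (0.35 log units; beyond the scatter), shows that turning the free amine of compound 1 into an acetamide gave a modestly weaker inhibitor.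

Compound 3, `COCCN[C@@H](CC(C)C)c1cc(C(F)(F)F)ccc1N1CCN(C(=O)CCc2ccc(Cl)cc2Cl)CC1`, has not yet been measured in this assay. It differs from compound 2 in one place: 1-((2-methoxyethyl)amino)-3-methylbutyl in place of 1-acetamido-2-methylbutyl on an aromatic carbon. The amide is thereby undone and a hydrogen-bearing amine returns, as in compound 1, though now carrying a 2-methoxyethyl group and with the chain renamed as 3-methylbutyl. Only a 2.3-fold higher number from compound 1 to compound 2 (0.35 log units; beyond the scatter) bears on this change, and it points to a modest drop in the number when the acetamide is removed. Compound 3 is therefore expected to give roughly 150 nM, within 40 nM to 600 nM, which would mean a 2.4-fold lower number from compound 2 to compound 3 (0.38 log units; beyond the scatter).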

Compound 3, inhibition constant: 620 nM
Beside the measured number, compound 3's estimate is 4.1-fold (0.62 log units) below it; the whole stated range lies below it.
By their numbers in this assay, from the lowest: compound 1; then compounds 2 and 3 (each within the scatter of the next).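

In this assay, replacing the 1-acetamido-2-methylbutyl group with 1-((2-methoxyethyl)amino)-3-methylbutyl gives a 1.7-fold higher number from compound 2 to compound 3 (0.24 log units; within the scatter), so this position does not distinguish between these two groups. A hydrogen-bearing amine alone is therefore not enough to match compound 1, as a 3.9-fold higher number from compound 1 to compound 3 (0.59 log units; beyond the scatter) is the step seen with the new group in place of 1-amino-2-methylbutyl. No supporting measurement is available to explain these results.

Going by these compounds, the step from compound 1 to compound 3 combines two changes, the 2-methoxyethyl group on the nitrogen and the move from a 2-methylbutyl to a 3-methylbutyl chain, so their separate contributions remain unknown. A 1-amino-3-methylbutyl group would separate them, while a simple methylamine would show whether a smaller group on the nitrogen behaves like the 2-methoxyethyl group.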